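Working notes: expected read-out for compound 4

The source may report more compounds than this note shows. Statements on the series, on what has been measured and on what is new or still open speak of the compounds shown alone.

Measured so far in a functional assay on MOLT-4 cells (Homo sapiens) for cytotoxicity, read by sulforhodamine B assay, with a stated time of 48 h, tested at 1 uM; a higher number here means a weaker effect of the compound at the concentration tested, a lower number a stronger effect:
- compound 1 `COc1ccc(-c2cc(/C=C/C(=O)c3ccc(OC)c(OC)c3)[nH]n2)cc1`: 95%
- compound 2 `COc1cc(-c2cc(/C=C/C(=O)c3ccc(Cl)c(Cl)c3)[nH]n2)cc(OC)c1OC`: 97%
- compound 3 `COc1ccc(-c2cc(/C=C/C(=O)c3ccc(N)cc3)[nH]n2)cc1OC`: 93%

Compound 2 holds the highest of the three numbers in this assay, but its separation from compound 1 and from compound 3 lies within the usual scatter, so the three read-outs are treated as one level; no ordering among them is claimed. Within the data shown here, no pair of measured compounds differs in only one place, so no measured step is available to carry forward.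

Compound 4 `COc1ccc(C(=O)/C=C/c2cc(-c3cc(OC)c(OC)c(OC)c3)n[nH]2)cc1OC` has not yet been measured. Against compound 2 the change is 3,4-dimethoxyphenyl in place of 3,4-dichlorophenyl on a carbonyl carbon. The closest measured reference for this group on the carbonyl carbon is compound 1, which carries the same 3,4-dimethoxyphenyl there and sits at the common level with 95%. Among the measured compounds shown here, with every measured compound at this level and no measured step to point elsewhere, the step from compound 2 to compound 4 in this assay is expected to be none beyond the scatter, in either direction: a number 2 percentage points lower from compound 2 to compound 4 (within the scatter). For compound 4 the expected read-out in this assay is therefore 95%, with a range from 85% to 103%.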

Compound 4, a percentage reported as activity, at one concentration (the size of the read-out at that concentration, not a potency): 88%
Beside the measured number, compound 4's estimate is 7 percentage points above it; the range from low to high includes it.
By their numbers in this assay, from the lowest: compounds 4, 3, 1 and 2 (each within the scatter of the next).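

Among these compounds, this is the first step read at this position, on a carbonyl carbon: in this assay, 3,4-dimethoxyphenyl in place of 3,4-dichlorophenyl gives a number 9 percentage points lower from compound 2 to compound 4 (within the scatter), so this change does not separate the two compounds. The exchange is a substantial one by the counts alone, with 10 heavy atoms and 2 hydrogen-bond acceptors entering where 8 heavy atoms and 0 hydrogen-bond acceptors leave, yet the read-out of this single pair stays at one level. Nothing measured here accounts for this result or tells what the position demands.

On these data alone, it remains open whether a group of another kind on this carbonyl carbon, such as a carboxylic acid or a saturated cyclohexyl ring, would take the read-out in this assay beyond the scatter. As far as these compounds go, this read-out also gives the size of the effect at one concentration and not a potency, so whether compound 2 and compound 4 would separate at other concentrations remains unknown.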